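The source may report more compounds than this note shows. Statements on the series, on what has been measured and on what is new or still open speak of the compounds shown alone.

Measured compounds in a functional assay on HOS cells (Homo sapiens) for antiproliferative activity, read by sulforhodamine B assay; on this read-out lower numbers stand for stronger inhibition of growth and higher numbers for weaker inhibition of growth:

Compound 1 `CC[C@@H]1O[C@H](COCc2ccccc2)[C@@H](OCc2ccccc2)[C@H](OCc2ccccc2)[C@H]1O` — 34200 nM
Compound 2 `CC[C@H]1O[C@H](COCc2ccccc2)[C@@H](OCc2ccccc2)[C@H](OCc2ccccc2)[C@H]1O` — a limit of the assay, > 50000 nM
Compound 3 `CCC[C@@H]1O[C@H](CO)[C@@H](O)[C@H](O)[C@H]1O` — a limit of the assay, > 50000 nM

Within the data shown here, compound 1 is the only member of the series with a number in this assay; the other two values are limits. Among the measured compounds shown here, the one measured step that is a single-point change runs from compound 1 to compound 2: an at least 1.4-fold higher number from compound 1 to compound 2 (0.16 log units; that floor lies within the scatter), the two differing only in configuration as drawn. Its size is a floor set by the limit of > 50000 nM in this assay, at which 2 of the 3 values shown sit, and the change behind it is given by the fact that compounds 1 and 2 differ only in the configuration as drawn, so it says little about substituent changes. For the measured compounds named here, compound 3 differs from compound 1 in more than one place and sits at a limit, so no step is drawn between them.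

Compound 4 `O[C@@H]1[C@@H](OCc2ccccc2)[C@H](OCc2ccccc2)[C@@H](COCc2ccccc2)O[C@H]1Cc1ccccc1` is still to be measured. Relative to compound 1 it carries phenyl in place of methyl on a saturated chain carbon bound to a saturated ring carbon. Going by the values given here, no measured step touches this kind of change: the configuration step from compound 1 to compound 2 does not bear on it, and compound 3 offers only a limit. With compound 1 at 34200 nM as the sole anchor, the expected step is a 1.2-fold lower number from compound 1 to compound 4 (0.09 log units; within the scatter), that is, nothing clearly beyond the scatter in either direction. The estimate for compound 4 in this assay is therefore 28000 nM, with a range from 9000 nM to 90000 nM, and a real chance that only a limit is reported.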

Compound 4, concentration for 50% growth inhibition: 29200 nM
For compound 4 the middle estimate is 1.0-fold (0.02 log units) below the measured one; measured number inside the range.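

In this assay, the change from ethyl to benzyl gives a 1.2-fold lower number from compound 1 to compound 4 (0.07 log units; within the scatter), so phenyl in place of methyl on a saturated chain carbon bound to a saturated ring carbon produces no difference that can be read beyond the scatter. Compound 4 still returns a number, 29200 nM, rather than a limit, which shows that this place in the core of compound 1 can carry a six-membered aromatic ring of carbon only with the read-out staying measurable. Among these compounds, the earlier single-point step concerned configuration only, so this is the first reading of a substituent change at this place.

Still open, from the compounds shown here alone, is whether an amine, a carboxylic acid or a longer chain on the same carbon would move the number beyond the scatter, and whether benzyl behaves the same way in the opposite configuration at the ring carbon. Any such reading has little room within the measurable range of this assay, as the upper end of the series shows: the limit of > 50000 nM in this assay, at which 2 of the 4 values shown sit.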